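Exposure notes: swapping the amine on the chain carbon

This account rests on a few compounds, and the source may have more. Where it says the series, first, only, none or still open, it means among the compounds named here.

Measured in an ADME assay on the whole organism for pharmacokinetics, with Mus musculus as the target, at a dose of 3 mg/kg by the intravenous route; on this read-out lower numbers stand for lower exposure and higher numbers for higher exposure at the dose given:
- compound 1 `CCC[C@H](C)Nc1ncc2c(-c3ccc(CN4CCCN(C)CC4)cc3)cn([C@H]3CC[C@H](O)CC3)c2n1`: 5200 nM
- compound 2 `CCC[C@H](C)Nc1ncc2c(-c3ccc(S(=O)(=O)N4CCN(C)CC4)cc3F)cn([C@H]3CC[C@H](O)CC3)c2n1`: 6500 nM

The value of compound 1 lies within the usual scatter of the value of compound 2, so neither stands apart. Compound 3 `CCC[C@H](C)Nc1ncc2c(-c3ccc(CNCCN(CC)CC)cc3)cn([C@H]3CC[C@H](O)CC3)c2n1` has not yet been measured. It differs from compound 1 as follows: (2-(diethylamino)ethyl)amino in place of 4-methyl-1,4-diazepan-1-yl on a saturated chain carbon bound to an aromatic carbon, with (2-(diethylamino)ethyl)amino in place of 4-methyl-1,4-diazepan-1-yl on a saturated chain carbon bound to an aromatic carbon. Within the data shown here, no measured pair shows this change, so the expectation is weakly grounded. The expected step of a 1.2-fold lower number from compound 1 to compound 3 (0.09 log units; within the scatter) stays within the scatter. For compound 3 the estimated value is 4200 nM, with an expected range of 2000 nM to 8500 nM.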

Compound 3, maximal plasma concentration: 1700 nM
For compound 3 the middle estimate is 2.5-fold (0.39 log units) above the measured one, outside the stated range (below it).
By their numbers in this assay, from the lowest: compound 3; then compounds 1 and 2 (each within the scatter of the next).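

In this assay, (2-(diethylamino)ethyl)amino in place of 4-methyl-1,4-diazepan-1-yl gives a 3.1-fold lower number from compound 1 to compound 3 (0.49 log units; beyond the scatter), so exposure at this place on the saturated chain carbon depends on which amine it carries, even with the same count of heavy atoms. The change removes the ring and adds a hydrogen-bond donor, and this single pair cannot separate those two differences. No measurement at hand accounts for the step. Still open, on these data alone, is whether the open chain with a methyl group in place of its amine hydrogen stays at the lower number. Also open, as far as these compounds go, is how 4-methylpiperazin-1-yl reads at this place.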